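Chloro to hydroxy on the aromatic ring: compound 3

The source may report more compounds than this note shows. Statements on the series, on what has been measured and on what is new or still open speak of the compounds shown alone.

- compound 1 `N#C/C(=C/c1ccc(Cl)cc1)C(=O)c1ccc[nH]1`: 75000 nM
- compound 2 `N#C/C(=C/c1ccc(Cl)c(Cl)c1)C(=O)c1ccc[nH]1`: < 10000 nM (a limit, not a number)

Within the data shown here, in a functional assay on A2780 cells (Homo sapiens) for cytotoxicity, read by MTT assay, with a stated time of 72 h (on this read-out lower numbers stand for stronger inhibition of growth and higher numbers for weaker inhibition of growth), compound 1 gives 75000 nM, the only exact number so far. Compound 2 is known only as a limit of the assay, < 10000 nM.

Compound 3 `N#C/C(=C/c1ccc(O)cc1)C(=O)c1ccc[nH]1` has not yet been measured. Its difference from compound 1 is hydroxy in place of chloro on an aromatic carbon. Among the measured compounds shown here, the one measured step, an at least 7.5-fold lower number from compound 1 to compound 2 (0.87 log units; beyond the scatter), adds a chloro rather than exchanging one, so it bears on this change only indirectly. For the measured compounds named here, no measured step exchanges the chloro, so no direction can be drawn from the data, and no change beyond the scatter is firmly expected. The expected step is a 1.1-fold lower number from compound 1 to compound 3 (0.03 log units; within the scatter), with wide uncertainty. For compound 3 the estimated value is 70000 nM, with an expected range of 15000 nM to 250000 nM.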

Compound 3, concentration for 50% growth inhibition: < 10000 nM
Compound 3 gave a limit, no number; the forecaster's own chance of this, stated with the estimate: 25%; middle value at least 7.0-fold (0.84 log units) from the limit.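

In this assay, hydroxy in place of chloro on an aromatic carbon, para to a large group, gives an at least 7.5-fold lower number from compound 1 to compound 3 (0.87 log units; beyond the scatter). The earlier step showed a lower number only with a chloro added to the chloro of compound 1; here the number is also lower with that chloro gone, so in this pair of compounds the chloro at this place is not needed for the lower number. The full size of the step cannot be read, because the value of compound 3 is a limit, not a number: the limit of < 10000 nM in this assay, at which 2 of the 3 values shown sit.

Compound 2 and compound 3 differ in more than one place and both stand as limits, so no order between them can be read. Also open, from the compounds shown here alone, is how an amine, a methoxy group or a carboxylic acid at this place on the ring would read in this assay.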